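A few compounds are considered here, and "the series" means these few. Any claim that something is new, unique, unknown or untested is made for them only; others in the source may bear on it.

Notes on the series in an ADME assay on Raji cells (Homo sapiens) for cytotoxicity, read by luminescence, with a stated time of 72 h (on this read-out lower numbers stand for an effect already at smaller amounts and higher numbers for an effect only at larger amounts of compound), where every compound so far returns only a limit. Compound 1 (`CCOC(=O)c1c(-c2cccc(-c3ccccc3)c2)[nH]c2cc(Cl)ccc2c1=O`) gives > 21500 nM here, a limit and not a number. Compound 2 (`CCOC(=O)c1c(-c2cccc(-c3ccccc3)c2)[nH]c2cc(Cl)c(OC)cc2c1=O`) gives > 21500 nM in this assay, again a limit and not a number. Compound 3 (`CCOC(=O)c1c(-c2cccc(Oc3ccccc3)c2)[nH]c2cc(Cl)c(OC)cc2c1=O`) gives > 21500 nM as well, also a limit. Compound 2 therefore has no readable place within the series, and all three sit together (the limit of > 21500 nM in this assay, at which 3 of the 3 values shown sit) at the same limit.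

The next change gives compound 4 (`CCOC(=O)c1c(-c2cccc(-c3ccccc3)c2)[nH]c2cc(Cl)c(Cl)cc2c1=O`), which has chloro in place of methoxy on an aromatic carbon, ortho to a chloro group, relative to compound 2 (chloro in place of methoxy on an aromatic carbon) on the shared core. The nearest measured change concerns the same aromatic carbon and gives a step that the two limits leave unreadable from compound 1 to compound 2 for methoxy in place of hydrogen. The change elsewhere, phenoxy in place of phenyl, gives a step that the two limits leave unreadable from compound 2 to compound 3 and is less relevant. Neither offers a size to carry over. Given the limit of > 21500 nM in this assay, at which 3 of the 3 values shown sit, and a step that the two limits leave unreadable from compound 1 to compound 2 as the only guide, no step beyond the scatter and no direction is expected in this assay. The expected step is a step that the limit leaves unreadable from compound 2 to compound 4 as an estimate only. For compound 4 the estimated value is 25000 nM with an expected range from 12000 nM to 50000 nM and a report as a limit is the likeliest outcome.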

Compound 4, half-maximal effective concentration: > 21500 nM
Compound 4 ended at the assay's limit; the forecaster's own chance of this, stated with the estimate: 85%; the middle value does not contradict the limit.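

In this assay compound 4 gives > 21500 nM, again a limit and not a number, so neither its step from compound 2 nor its step from compound 1 can be read. The series stays at a single limit: the limit of > 21500 nM in this assay, at which 4 of the 4 values shown sit.

The compounds shown leave open whether any change on the shared core gives a readable value in this assay.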